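Cyano Added to the Methylphenyl Ring: Expected Cytotoxicity

The compounds below may be only part of what the source reports. "The series", "measured", "known", "first", "only" and "open" are said of these compounds alone.

Compound 1 `Cc1ccccc1-c1cncc(NCc2cc(-c3ccccc3)[nH]n2)c1` and compound 2 `Cc1ccccc1-c1ccnc(NCc2cc(-c3ccccc3)[nH]n2)c1` share the same atoms joined differently; the difference between the two cores is not broken down here. Compound 3 `Cc1cc(C#N)ccc1-c1cncc(NCc2cc(-c3ccccc3)[nH]n2)c1` arises from compound 1 by the change (cyano in place of hydrogen on an aromatic carbon). In an ADME assay on CEM174 cells (Homo sapiens) for cytotoxicity (a lower number here means that less compound is tolerated, a higher number that more compound is tolerated), compound 1 gives only a limit of > 10000 nM. In this assay compound 2 likewise gives only a limit of > 10000 nM. Compound 3 also gives only a limit of > 10000 nM in this assay. The step that the two limits leave unreadable from compound 1 to compound 3 therefore cannot be sized, because the limit of > 10000 nM in this assay, at which 3 of the 3 values shown sit, holds for every value shown. Within the data shown here, compound 4 `Cc1cc(C#N)ccc1-c1ccnc(NCc2cc(-c3ccccc3)[nH]n2)c1`, not yet measured, arises from compound 2 by the change (cyano in place of hydrogen on an aromatic carbon), the same change as the one from compound 1 to compound 3, at the same place on the ring. Since compound 2 sits at the limit of > 10000 nM and the earlier change left compound 3 at the limit, the step that the limit leaves unreadable from compound 2 to compound 4 is expected to be small. Compound 4 is estimated at 15000 nM in this assay, most likely reported again only as a limit.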

Compound 4, half-maximal cytotoxic concentration: > 10000 nM
Compound 4: only a limit was reported; the forecaster's own chance of this, stated with the estimate: 85%; the middle value lies beyond the limit too.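

No step can be read from compound 2 to compound 4, because both give only a limit and not a number: the limit of > 10000 nM in this assay, at which 4 of the 4 values shown sit. The compounds shown leave open what concentration of any of them is actually cytotoxic in this assay, and whether adding the cyano group shifts that concentration at all.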